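A few compounds are considered here, and "the series" means these few. Any claim that something is new, unique, unknown or untested is made for them only; others in the source may bear on it.

Measured so far:

Compound 1 `CC1COC2(C=CC(=O)C=C2)N(C(C)C)C1=O` gives > 20000 nM in an assay on isolated protein for inhibition of N-lysine methyltransferase SMYD2 (Homo sapiens), read by filter binding, with a stated time of 1 h; on this read-out lower numbers stand for stronger inhibition and higher numbers for weaker inhibition; this is a limit of the assay, not a number.
Compound 2 `CN1C(=O)C(CCNc2ccccc2)COC12C=CC(=O)C=C2` gives > 20000 nM in this assay; this too is a limit of the assay, not a number.

Among the compounds with values here, compound 2 therefore stands only at a limit, and the one further value shown is also a limit, so that both values shown sit at the limit of > 20000 nM in this assay, at which 2 of the 2 values shown sit. Within the data shown here, no step between two measured compounds that differ in one place can be drawn from these two.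

Compound 3 `CN1C(=O)C(CCNc2ccc(Cl)c(Cl)c2)COC12C=CC(=O)C=C2` differs from compound 2 in one place: 3,4-dichlorophenyl in place of phenyl on an amine nitrogen. Among the measured compounds shown here, with no measured step to lean on, and with compound 2 giving only > 20000 nM, the change carries no expectation of a shift beyond the scatter in either direction. The step of an at least 1.3-fold lower number from compound 2 to compound 3 (0.12 log units; that floor lies within the scatter) is expected to be one of no change beyond the scatter. Compound 3 is expected to give 15000 nM in this assay, in a range from 3000 nM to 60000 nM.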

Compound 3, half-maximal inhibitory concentration: 3820 nM
The estimate for compound 3 lay 3.9-fold (0.59 log units) above the measured number; low and high end bracket the measured number.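

Compound 3 is the only one of the compounds shown that gives a number rather than a limit in this assay, so this is the first sign that the aromatic ring on the amine nitrogen is a place where a change can be read at all. Setting 3,4-dichlorophenyl in place of phenyl on an amine nitrogen brings an at least 5.2-fold lower number from compound 2 to compound 3 (0.71 log units; beyond the scatter) and this shift lies beyond the scatter, with the saturated chain and the shared core left as they are. As far as these compounds go, the full size of the step stays unknown because compound 2 stands at a limit of the assay and not at a number: the limit of > 20000 nM in this assay, at which 2 of the 3 values shown sit.

The compounds shown leave open whether both chlorine atoms are needed, or whether a 3-chlorophenyl or a 4-chlorophenyl alone would give a similar number. They also leave open how a bromine or a trifluoromethyl on the ring, a longer chain, or an amide in place of the amine would read in this assay, and whether any such change would carry the number further down.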